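Swapping the amine on a thiocarbonyl carbon

The source may report more compounds than this note shows. Statements on the series, on what has been measured and on what is new or still open speak of the compounds shown alone.

In a functional assay on HeLa cells (Homo sapiens) for antiproliferative activity, read by CCK-8 assay, with a stated time of 72 h, tested at 8 uM (on this read-out higher numbers stand for a stronger effect at the one concentration tested and lower numbers for a weaker effect), compound 1 `Nc1ccccc1NC(=O)c1ccc(CSC(=S)N2CCN(c3ccccc3)CC2)cc1` gives 73.1% and compound 2 `Nc1ccccc1NC(=O)c1ccc(CSC(=S)N2CCc3ccccc32)cc1` gives 67%; the two numbers lie within the scatter of each other, so neither can be set apart from the other. Compound 3 `CN(C(=S)SCc1ccc(C(=O)Nc2ccccc2N)cc1)c1cccnc1` has not yet been measured in this assay. It differs from compound 2 by methyl(pyridin-3-yl)amino in place of 2,3-dihydro-1H-indol-1-yl on a thiocarbonyl carbon. Within the data shown here, no measured pair shows this kind of change, so the step of a number 4 percentage points lower from compound 2 to compound 3 (within the scatter) is expected to stay within the scatter rather than move the read-out clearly in either direction. Compound 3 is therefore estimated at 63%, with a range from 42% to 80%.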

Compound 3, a percentage reported as inhibition, at one concentration (the size of the read-out at that concentration, not a potency): 70.5%
Compound 3: the middle estimate sits 7.5 percentage points below what was measured; the range from low to high includes it.
By their numbers in this assay, from the lowest: compounds 2, 3 and 1 (each within the scatter of the next).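

In this assay, methyl(pyridin-3-yl)amino in place of 2,3-dihydro-1H-indol-1-yl on a thiocarbonyl carbon gives a number 3.5 percentage points higher from compound 2 to compound 3 (within the scatter), the first step measured at this position. The read-out therefore holds when the five-membered non-aromatic ring leaves and a six-membered aromatic ring with a hetero atom enters. No available evidence bears on why this exchange leaves the read-out within the scatter. As far as these compounds go, it remains open whether a small amine such as dimethylamine, or a morpholine, would also hold the read-out on this carbon. A single concentration also leaves open whether these compounds would show a stronger or weaker effect at other concentrations.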